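Swapping methylsulfanyl for trifluoromethyl on the aryl ring

The source may report more compounds than this note shows. Statements on the series, on what has been measured and on what is new or still open speak of the compounds shown alone.

The three measured compounds share one core and differ only in a single group on an aromatic ring. Compound 1 `O=C(O)c1cccc(CCCCCCC(=O)c2ncc(-c3ccccn3)o2)c1` carries a carboxy group there; in an assay for inhibition of Fatty-acid amide hydrolase 1 (Rattus norvegicus) (on this read-out higher numbers stand for weaker inhibition and lower numbers for stronger inhibition), compound 1 gives only the limit > 600 nM, not a number. Compound 2 `CC(C)(C)OC(=O)Nc1cccc(CCCCCCC(=O)c2ncc(-c3ccccn3)o2)c1` gives 2.4 nM in this assay, and compound 3 `CSc1cccc(CCCCCCC(=O)c2ncc(-c3ccccn3)o2)c1` gives 4.2 nM. Of the two numbers, compound 3 stands highest, with compound 2 nearest at a 1.8-fold higher number from compound 2 to compound 3 (0.24 log units; within the scatter). Compound 4 `O=C(CCCCCCc1cccc(C(F)(F)F)c1)c1ncc(-c2ccccn2)o1` differs from compound 3 by trifluoromethyl in place of methylsulfanyl on an aromatic carbon. The steps of an at least 140-fold lower number from compound 1 to compound 3 (2.15 log units; beyond the scatter) and an at least 250-fold lower number from compound 1 to compound 2 (2.39 log units; beyond the scatter) were large, whereas exchanging one non-carboxy group for another gave a small step. A similar small step is expected here, so compound 4 is estimated at 6 nM, between 2 nM and 20 nM, a step of a 1.4-fold higher number from compound 3 to compound 4 (0.15 log units; within the scatter).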

Compound 4, inhibition constant: 1 nM
For compound 4 the middle estimate is 6.0-fold (0.78 log units) above the measured one, and the stated range ends above it.
By their numbers in this assay, from the lowest: compound 4; then compounds 2 and 3 (each within the scatter of the next). At a limit, above all of these: compound 1.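

Compounds 2 and 3 could not be told apart in this assay, but trifluoromethyl separates from both, with a 4.2-fold lower number from compound 3 to compound 4 (0.62 log units; beyond the scatter) and a 2.4-fold lower number from compound 2 to compound 4 (0.38 log units; beyond the scatter). This position therefore responds to exchanges among non-carboxy groups as well, and compound 4 has the lowest number of the four. Compound 1 gives a limit and not a number, so the exchange of carboxy, an at least 600-fold lower number from compound 1 to compound 4 (2.77 log units; beyond the scatter), is only a bound: the limit of > 600 nM in this assay, at which 1 of the 4 values shown sits.

On these data alone, how an amine, a nitrile or a chloro group would read on this aromatic carbon stays open. So does whether trifluoromethyl would give a similar number elsewhere on the ring.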